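Aryl variation on an oxadiazole-bearing core: three measured, one expected

A few compounds are considered here, and "the series" means these few. Any claim that something is new, unique, unknown or untested is made for them only; others in the source may bear on it.

Compound 1 `CS(=O)(=O)c1ccc(-c2cnc3[nH]cc(-c4nnc(-c5ccc(F)cc5)o4)c(=O)c3c2)cc1` gives 9.45%. Compound 2 `CS(=O)(=O)c1ccc(-c2cnc3[nH]cc(-c4nnc(-c5ccccc5)o4)c(=O)c3c2)cc1` gives 5.46%. Compound 3 `CS(=O)(=O)c1ccc(-c2cnc3[nH]cc(-c4nnc(-c5ccc(Cl)cc5)o4)c(=O)c3c2)cc1` gives 11.3%.

These numbers come from a functional assay on HepG2 cells (Homo sapiens) for inhibition, read by MTT assay, with a stated time of 24 h, tested at 5 uM; a higher number here means more inhibition of growth at the concentration tested, a lower number less inhibition of growth. Compound 3 sits at the upper edge of the three, yet its steps to the others are small: a number 1.9 percentage points higher from compound 1 to compound 3 (within the scatter) and a number 5.8 percentage points higher from compound 2 to compound 3 (within the scatter). The step from compound 1 to compound 2, a number 4 percentage points lower from compound 1 to compound 2 (within the scatter), is likewise within the scatter, so the three values cannot be separated.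

Compound 4 `Cc1cccc(-c2nnc(-c3c[nH]c4ncc(-c5ccc(S(C)(=O)=O)cc5)cc4c3=O)o2)c1` differs from compound 3 in one place: 3-methylphenyl in place of 4-chlorophenyl on an aromatic carbon. The measured steps that bear on this are the two aryl substituent swaps into compound 3, both within the scatter, so no step beyond the scatter is expected here. Compound 4 is therefore estimated at 8.5%, ranging from 0% to 18%, meaning an expected step of a number 2.8 percentage points lower from compound 3 to compound 4 (within the scatter).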

Compound 4, percent growth inhibition at one concentration: 13.2%
For compound 4 the middle estimate is 4.7 percentage points below the measured one, and the stated range covers the measured number.
By their numbers in this assay, from the lowest: compounds 2, 1, 3 and 4 (each within the scatter of the next).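

At this aromatic carbon, 3-methylphenyl gives a reading in this assay that cannot be separated from those of the other aryl groups: a number 1.9 percentage points higher from compound 3 to compound 4 (within the scatter), a number 3.8 percentage points higher from compound 1 to compound 4 (within the scatter) and a number 7.7 percentage points higher from compound 2 to compound 4 (within the scatter). The band therefore holds for a methyl group at another ring position as well as for the halogens, so this change opens no measurable difference. Nothing measured here offers an explanation for these readings.

As far as these compounds go, it remains open whether an amine, a carboxylic acid or a longer chain on this phenyl ring would move the reading beyond the scatter.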